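The source may report more compounds than this note shows. Statements on the series, on what has been measured and on what is new or still open speak of the compounds shown alone.

Measured so far in a functional assay on PC-3 cells (Homo sapiens) for cytotoxicity, read by MTT assay, with a stated time of 72 h; on this read-out higher numbers stand for weaker inhibition and lower numbers for stronger inhibition:
compound 1, `COc1cc(-c2cncc(N[C@@H](C)c3ccccc3)n2)ccc1O`, gives 10000 nM
compound 2, `CCC[C@H](Nc1cncc(-c2ccc(O)c(OC)c2)n1)c1ccccc1`, gives 160 nM
compound 3, `CCCC(Nc1cncc(-c2ccc(NC(C)=O)c(OC)c2)n1)c1cccnc1`, gives 5000 nM

Compound 2 differs from compound 1 by ethyl in place of hydrogen on a saturated chain carbon, two bonds along the chain from an aromatic carbon and a nitrogen on an aromatic ring, and this step gave a 63-fold lower number from compound 1 to compound 2 (1.80 log units; beyond the scatter). Compound 3 carries a different core; the difference between the cores of compound 1 and compound 3 is not broken down here, and their two values lie within the scatter of each other.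

Compound 4, `CCCC(=O)Nc1ccc(-c2cncc(NC(CCC)c3cccnc3)n2)cc1OC`, is not yet measured and differs from compound 3 by ethyl in place of hydrogen on a saturated chain carbon bound to a carbonyl carbon. This is the same kind of change as from compound 1 to compound 2, but the place differs: there the ethyl entered on a saturated chain carbon two bonds along the chain from an aromatic carbon and a nitrogen on an aromatic ring, here on a saturated chain carbon bound to a carbonyl carbon. Among the compounds with values here, a smaller step is expected because the earlier step of a 63-fold lower number from compound 1 to compound 2 (1.80 log units; beyond the scatter) arose at another place and the amide chain has no precedent here. The expected step from compound 3 is a 2.0-fold lower number from compound 3 to compound 4 (0.30 log units; within the scatter) in this assay. Compound 4 is estimated at 2500 nM in this assay.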

Compound 4, half-maximal inhibitory concentration: 600 nM
For compound 4 the middle estimate is 4.2-fold (0.62 log units) above the measured one; measured number below the stated range.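

In this assay, ethyl in place of hydrogen on a saturated chain carbon bound to a carbonyl carbon gives an 8.3-fold lower number from compound 3 to compound 4 (0.92 log units; beyond the scatter), so the direction seen on the earlier pair recurs on the second core. The size of the step does not carry over: the same change on two cores in this assay, a 63-fold lower number (1.80 log units; beyond the scatter) from compound 1 to compound 2 and an 8.3-fold lower number (0.92 log units; beyond the scatter) from compound 3 to compound 4, 7.5-fold (0.88 log units) apart, beyond the scatter of two such steps. These pairs differ in the place of the ethyl as well as in the core, so the gap cannot be assigned to either difference, and two pairs establish no rule for the series.

From the compounds shown here alone, it remains open whether a longer chain, such as pentylcarbonyl, would lower the number further than propylcarbonyl does. Also open, going by these compounds, is how an amine or a carboxylic acid at the end of that chain would read in this assay.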